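Hydroxymethyl Gives Way to Amino on the Chain

The source may report more compounds than this note shows. Statements on the series, on what has been measured and on what is new or still open speak of the compounds shown alone.

In an ADME assay on L6 cells (Rattus norvegicus) for cytotoxicity, read by fluorescence, with a stated time of 72 h (on this read-out higher numbers stand for weaker inhibition and lower numbers for stronger inhibition), compound 3 `OCCCNc1ccnc2cc(Cl)ccc12` gives 178000 nM, within the scatter of both compound 1 `OCCNc1ccnc2cc(Cl)ccc12` at 233000 nM and compound 2 `COc1cc(NC(C)CCCNC(c2cccc(CO[C@@H]3COc4nc([N+](=O)[O-])cn4C3)c2)c2nnnn2C(C)(C)C)c2ncccc2c1` at 143000 nM. Compound 4 `NCCNc1ccnc2cc(Cl)ccc12` has not yet been measured. It departs from compound 3 as follows: amino in place of hydroxymethyl on a saturated chain carbon, two bonds along the chain from a nitrogen on an aromatic ring. The change is amino in place of hydroxymethyl on a saturated chain carbon, two bonds along the chain from a nitrogen on an aromatic ring. Within the data shown here, one measured step bears on that place, a 1.3-fold lower number from compound 1 to compound 3 (0.12 log units; within the scatter), though no measured step brings in an amino group. The estimated change is a 1.5-fold lower number from compound 3 to compound 4 (0.17 log units; within the scatter), so no step beyond the scatter is expected in this assay. Compound 4 is expected at 120000 nM, within an estimated range of 50000 nM to 260000 nM.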

Compound 4, half-maximal inhibitory concentration: 21200 nM
For compound 4 the middle estimate is 5.7-fold (0.75 log units) above the measured one, outside the stated range (below it).
By their numbers in this assay, from the lowest: compound 4; then compounds 2, 3 and 1 (each within the scatter of the next).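

Across the hydroxy compounds, the change at this place had moved the number only within the scatter in this assay, so the position had seemed insensitive to what the chain carried. Amino changes that picture, giving an 8.4-fold lower number from compound 3 to compound 4 (0.92 log units; beyond the scatter) and an 11-fold lower number from compound 1 to compound 4 (1.04 log units; beyond the scatter), so at this place the identity of the group matters, not just the presence of a group with a hydrogen-bond donor and acceptor. No measured evidence accounts for this difference. Going by these compounds, whether a longer chain bearing the amino group, a methylated amine or a carboxylic acid would give a similar step remains open.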